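Amide substituent change in a Caco-2 antiproliferative series

A few compounds are considered here, and "the series" means these few. Any claim that something is new, unique, unknown or untested is made for them only; others in the source may bear on it.

Compound 1 `CCn1c(C(=O)Nc2cccc(C(F)(F)F)c2)ccc1C(CC)(CC)c1ccc(OCCC(O)(CC)CC)c(C)c1`: > 50000 nM
Compound 2 `CCOc1ccc(NC(=O)c2ccc(C(CC)(CC)c3ccc(OCCC(O)(CC)CC)c(C)c3)n2CC)cc1`: > 50000 nM

In a functional assay on Caco-2 cells (Homo sapiens) for antiproliferative activity, read by MTT assay, with a stated time of 48 h (a lower number here means a stronger inhibitor, a higher number a weaker inhibitor), compound 1 gives only a limit, > 50000 nM. Compound 2 likewise gives only a limit, > 50000 nM. The step that the two limits leave unreadable from compound 1 to compound 2 cannot be read, since both values sit at the limit of > 50000 nM in this assay, at which 2 of the 2 values shown sit. Compound 3 `CCn1c(C(=O)NC(CO)CCO)ccc1C(CC)(CC)c1ccc(OCCC(O)(CC)CC)c(C)c1` alters the amide substituent of compound 2: 3-hydroxy-1-(hydroxymethyl)propyl in place of 4-ethoxyphenyl on an amide-type nitrogen. Going by the values given here, no measured step bears on this change, and nothing measured sets compound 2 anywhere but at the limit. Compound 3 is therefore expected to remain at the limit as well, estimated at 50000 nM with a range from 15000 nM to 100000 nM. The step of a number no higher from compound 2 to compound 3 (the limit leaves the size open) is expected to show no readable change.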

Compound 3, half-maximal inhibitory concentration: 40200 nM
For compound 3 the middle estimate is 1.2-fold (0.09 log units) above the measured one, within the range that was stated.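

Going by these compounds alone, compound 3 gives the first value in this assay that is a number and not a limit, so a substituent without a ring on the amide-type nitrogen can bring a readable result. As far as these compounds go, the change gives an at least 1.2-fold lower number from compound 2 to compound 3 (0.09 log units; that floor lies within the scatter) and an at least 1.2-fold lower number from compound 1 to compound 3 (0.09 log units; that floor lies within the scatter); both are floors only, and the real size of each step stays open. Most of the compounds shown still give no number: the limit of > 50000 nM in this assay, at which 2 of the 3 values shown sit.

The step from compound 1 to compound 2 cannot be read. From the compounds shown here alone, whether an amine or a carboxylic acid on this chain would shift the value stays open.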